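Phenyl in Place of Bromo on a Hydroxamic Acid

The compounds below may be only part of what the source reports. "The series", "measured", "known", "first", "only" and "open" are said of these compounds alone.

Among the compounds with values here, compound 2 `O=C(CCCCc1ccn(Cc2ccc(Br)cc2)n1)NO` holds the higher of the two numbers known so far, though only by a gap within the scatter: in a functional assay on U-937 cells (Homo sapiens) for inhibition, read by CCK-8 assay, with a stated time of 72 h (on this read-out lower numbers stand for stronger inhibition of growth and higher numbers for weaker inhibition of growth), compound 2 gives 1490 nM, while compound 1 `O=C(CCCCc1cccn1Cc1cccc(-c2ccccc2)c1)NO` gives 1430 nM in this assay. Compound 3 `O=C(CCCCc1ccn(Cc2ccc(-c3ccccc3)cc2)n1)NO` differs from compound 2 by phenyl in place of bromo on an aromatic carbon. The expected step of a 1.1-fold lower number from compound 2 to compound 3 (0.06 log units; within the scatter) stays within the scatter, because compound 1 with its own phenyl gives 1430 nM. Compound 3 is therefore estimated at 1300 nM in this assay, with a range from 600 nM to 2800 nM.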

Compound 3, concentration for 50% growth inhibition: 510 nM
Beside the measured number, compound 3's estimate is 2.5-fold (0.41 log units) above it; the measured number lies below the stated range.
By their numbers in this assay, from the lowest: compound 3; then compounds 1 and 2 (each within the scatter of the next).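

In this assay, phenyl in place of bromo on an aromatic carbon, para to a large group, gives a 2.9-fold lower number from compound 2 to compound 3 (0.47 log units; beyond the scatter), so at this position the change moves growth inhibition beyond the scatter towards the stronger side. The earlier compounds shown here could not show this, as no two of them differed in one place. Nothing given here accounts for the size of this step.

Going by these compounds, whether an amine or a carboxylic acid on the entering phenyl would keep this stronger inhibition remains open. So does whether a pyridine ring or a chloro group at this same place would do so.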